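Changing the Group on a Ring Nitrogen: Compound 1 to Compound 4

The compounds below may be only part of what the source reports. "The series", "measured", "known", "first", "only" and "open" are said of these compounds alone.

Compound 1, `Nc1ccccc1NC(=O)c1ccc(CSC(=S)N2CCN(c3ccc(F)cc3)CC2)cc1`, was tested in a functional assay on A-375 cells (Homo sapiens) for antiproliferative activity, read by CCK-8 assay, with a stated time of 72 h, tested at 2 uM (on this read-out higher numbers stand for a stronger effect at the one concentration tested and lower numbers for a weaker effect), and gives 20.9%. Among the three measured compounds this is the lowest number. Compound 2, `CCN(Cc1ccncc1)C(=S)SCc1ccc(C(=O)Nc2ccccc2N)cc1`, gives 67.2% in this assay, and compound 3, `CC1CCN(C(=S)SCc2ccc(C(=O)Nc3ccccc3N)cc2)CC1`, gives 32.7%. Compound 1 thus sits below compound 3 by a gap beyond the usual scatter, and much further below compound 2.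

The unmeasured compound 4, `Nc1ccccc1NC(=O)c1ccc(CSC(=S)N2CCN(C3CCCCC3)CC2)cc1`, differs from compound 1 in one place: cyclohexyl in place of 4-fluorophenyl on an amine nitrogen in a ring. For the measured compounds named here, the only measured step between two compounds that differ in one place is a number 34.5 percentage points lower from compound 2 to compound 3 (beyond the scatter). That step changes the group on the thiocarbonyl carbon, not the group on the ring nitrogen that is changed here, so it does not bear directly on the step to compound 4. Going by the values given here, nothing among the measured compounds varies the group on that ring nitrogen, and the starting point of compound 1 is already low. The expected step is therefore small, a number 9.1 percentage points higher from compound 1 to compound 4 (within the scatter), with no confident direction. Compound 4 is estimated to give 30% in this assay, within a range from 10% to 55%.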

Compound 4, a percentage reported as inhibition, at one concentration (the size of the read-out at that concentration, not a potency): 31.7%
Compound 4: the middle estimate sits 1.7 percentage points below what was measured, within the range that was stated.
By their numbers in this assay, from the lowest: compound 1; then compounds 4 and 3 (each within the scatter of the next); then compound 2.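

For the compounds shown here, this is the first measured change at the amine nitrogen in the six-membered non-aromatic ring, and in this assay the swap of 4-fluorophenyl for cyclohexyl gives a number 10.8 percentage points higher from compound 1 to compound 4 (beyond the scatter) and so shows that the group on this nitrogen can shift the read-out beyond the usual scatter, though only modestly. The swap changes two things at once, since an aromatic carbon ring becomes a non-aromatic one and the fluorine leaves, so this single pair cannot show which of the two changes accounts for the step. No separate measurement is available that explains the step.

A plain phenyl group on the same nitrogen would keep the aromatic ring without the fluorine, and its number could help to separate those two changes. On these data alone, it also remains open how a group of a different kind at this position, such as a pyridin-4-ylmethyl group or a short chain ending in an amine, would compare with the 4-fluorophenyl of compound 1 on the same core.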